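The compounds below may be only part of what the source reports. "The series", "measured", "known", "first", "only" and "open" are said of these compounds alone.

In an ADME assay on HEK-293T cells (Homo sapiens) for cytotoxicity, read by MTT assay, with a stated time of 24 h (a higher number here means that more compound is tolerated, a lower number that less compound is tolerated), compound 3 `COc1ccc(S(=O)(=O)n2c(-c3cn(-c4ccccc4)nc3-c3ccc(C(F)(F)F)cc3)nc3ccccc32)cc1` gives > 300000 nM, and this is a limit of the assay, not a number. For comparison, compound 1 `COc1ccc(S(=O)(=O)n2c(-c3cn(-c4ccccc4)nc3-c3ccc(F)cc3)nc3ccccc32)cc1` gives 37300 nM and compound 2 `O=S(=O)(c1ccc(Cl)cc1)n1c(-c2cn(-c3ccccc3)nc2-c2ccc(F)cc2)nc2ccccc21` gives 93100 nM. Compound 4 `O=S(=O)(c1ccc(Cl)cc1)n1c(-c2cn(-c3ccccc3)nc2-c2ccc(C(F)(F)F)cc2)nc2ccccc21` differs from compound 3 by chloro in place of methoxy on an aromatic carbon, para to a large group. The same exchange has been measured once, as a 2.5-fold higher number from compound 1 to compound 2 (0.40 log units; beyond the scatter), a modest move towards more compound being tolerated. The other measured change, trifluoromethyl in place of fluoro, gave an at least 8.0-fold higher number from compound 1 to compound 3 (0.90 log units; beyond the scatter). For the measured compounds named here, it sits elsewhere on the molecule, but it shows that both of these exchanges have raised the number so far. Going by the values given here, only one pair tests the chloro exchange, and compound 3 offers no exact starting number. A modest rise is therefore expected, and the result may again come back only as a limit. The expected step is a step that the limit leaves unreadable from compound 3 to compound 4. Compound 4 is estimated at 450000 nM, with an expected range of 150000 nM to 1000000 nM.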

Compound 4, half-maximal cytotoxic concentration: 75300 nM
Compound 4: middle estimate off by 6.0-fold (0.78 log units), on the high side, outside the stated range (below it).
By their numbers in this assay, from the lowest: compound 1; then compounds 4 and 2 (each within the scatter of the next). At a limit, above all of these: compound 3.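

In this assay, the change from 4-methoxyphenyl to 4-chlorophenyl now gives an at least 3.9-fold lower number from compound 3 to compound 4 (0.60 log units; beyond the scatter), so this exchange does not move the number the same way on every core: the same change on two cores in this assay, a 2.5-fold higher number (0.40 log units; beyond the scatter) from compound 1 to compound 2 and an at least 3.9-fold lower number (0.60 log units; beyond the scatter) from compound 3 to compound 4, at least 9.9-fold (0.99 log units) apart, beyond the scatter of two such steps

Trifluoromethyl in place of fluoro likewise loses its earlier rise, giving a 1.2-fold lower number from compound 2 to compound 4 (0.09 log units; within the scatter), a step that cannot be told apart from no change: the same change on two cores in this assay, an at least 8.0-fold higher number (0.90 log units; beyond the scatter) from compound 1 to compound 3 and a 1.2-fold lower number (0.09 log units; within the scatter) from compound 2 to compound 4, at least 9.9-fold (0.99 log units) apart, beyond the scatter of two such steps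

Among these four compounds, then, the two exchanges do not act independently, and the outcome of each depends on which group sits at the other place.

The value of compound 3, > 300000 nM, is a limit of the assay and not a number. From the compounds shown here alone, how large the step to compound 4 really is stays open, as does how an amine or a carboxylic acid at this position would behave on either core.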